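The source may report more compounds than this note shows. Statements on the series, on what has been measured and on what is new or still open speak of the compounds shown alone.

Within the data shown here, in a functional assay on V79 cells (Cricetulus griseus) for cytotoxicity, read by colony formation (a lower number here means a stronger inhibitor, a higher number a weaker inhibitor), three compounds have numbers so far. Compound 3 `CC1(CN)CCN(c2c(F)cc3c(=O)c(C(=O)O)cn(C4CC4)c3c2F)C1` stands lowest of the three (8 ug/mL), which makes it the strongest inhibitor among them. Compound 2 `CC1(CN)CCN(c2cc3c(cc2F)c(=O)c(C(=O)O)cn3C2CC2)C1` comes next (23 ug/mL), and compound 1 `CCNCC1CCN(c2c(F)cc3c(=O)c(C(=O)O)cn(C4CC4)c3c2C(F)(F)F)C1` has the highest number (120 ug/mL).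

The next compound, compound 4 `CC1(CN)CCN(c2c(F)cc3c(=O)c(C(=O)O)cn(C4CC4)c3c2C(F)(F)F)C1`, keeps compound 3 intact except for one group: trifluoromethyl in place of fluoro on an aromatic carbon, ortho to a 3-(aminomethyl)-3-methylpyrrolidin-1-yl group (trifluoromethyl in place of fluoro on an aromatic carbon).

Among the measured compounds shown here, only one measured step alters a single group on that carbon. It is a 2.9-fold lower number from compound 2 to compound 3 (0.46 log units; beyond the scatter) and comes from fluoro replacing hydrogen. This shows that the group on that carbon can move the number, but it does not show what a larger group would do. The nearest hint is compound 1 (120 ug/mL), which also carries trifluoromethyl on that carbon. Its side chain differs as well, so its high number cannot be credited to trifluoromethyl alone.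

A move towards a higher number in this assay is therefore expected, beyond the scatter but well short of the full gap to compound 1. The expected change is a 3.8-fold higher number from compound 3 to compound 4 (0.57 log units; beyond the scatter) as an estimate, with wide uncertainty. Compound 4 is estimated at 30 ug/mL (expected range 10 ug/mL to 90 ug/mL).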

Compound 4, half-maximal inhibitory concentration: 110 ug/mL
Estimate against measurement, compound 4: 3.7-fold (0.56 log units) below; measured number outside the range, above it.
By their numbers in this assay, from the lowest: compound 3; then compound 2; then compounds 4 and 1 (each within the scatter of the next).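

In this assay, trifluoromethyl in place of fluoro on this aromatic carbon, ortho to the 3-(aminomethyl)-3-methylpyrrolidin-1-yl group, gives a 14-fold higher number from compound 3 to compound 4 (1.14 log units; beyond the scatter); with the side chain held fixed, this single change accounts for a large step, something compound 1 could not show because its side chain differs as well. Measured against hydrogen on the same carbon, the two groups pull in opposite directions: fluoro gives a 2.9-fold lower number from compound 2 to compound 3 (0.46 log units; beyond the scatter), whereas trifluoromethyl gives a 4.8-fold higher number from compound 2 to compound 4 (0.68 log units; beyond the scatter). With trifluoromethyl in place, exchanging 3-((ethylamino)methyl)pyrrolidin-1-yl for 3-(aminomethyl)-3-methylpyrrolidin-1-yl gives a 1.1-fold lower number from compound 1 to compound 4 (0.04 log units; within the scatter), so these two side chains cannot be told apart in this setting.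

No measurement here explains why the number moves with the group on this carbon. Still open, from the compounds shown here alone, is where a methyl, a chloro or a methoxy group on that carbon would fall relative to fluoro and trifluoromethyl, and whether the two side chains would still match with fluoro there instead.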